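Chloro on the phenyl ring of a proline-based p300 inhibitor

The source may hold more compounds than are shown below. What is called first, only, known or untested is meant among the compounds shown, and "the series" means these compounds.

Compound 1, `COc1ccc(NC(=O)[C@H]2CCCN2C(=O)C2(c3ccccc3)CCCC2)cc1`, was tested in an assay on isolated protein for inhibition of histone acetyltransferase p300 (Homo sapiens), with a stated time of 60 min (on this read-out lower numbers stand for stronger inhibition and higher numbers for weaker inhibition), where compound 1 gives 79.4 nM. That is the highest of the two numbers recorded so far. For the measured compounds named here, the only comparison is compound 2, `O=C(Nc1ccc2[nH]ncc2n1)[C@H]1CCCN1C(=O)C1(c2ccc(F)cc2)CCC1`, which in this assay gives 0.126 nM, a number far below that of compound 1 and well beyond the scatter; the two compounds differ in several places at once, so the two values show only that compound 2 inhibits far more strongly than compound 1.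

Compound 3, `COc1ccc(NC(=O)[C@H]2CCCN2C(=O)C2(c3cccc(Cl)c3)CCCC2)cc1`, is related to compound 1 by a single change, (chloro in place of hydrogen on an aromatic carbon). Going by the values given here, no pair of measured compounds differing in this one place has been recorded, so the size of the step rests on expectation alone. A modest decrease in the number, at the edge of the scatter, is expected for the step of a 2.0-fold lower number from compound 1 to compound 3 (0.30 log units; within the scatter). In this assay compound 3 is therefore estimated to give 40 nM, within a range from 10 nM to 160 nM.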

Compound 3, half-maximal inhibitory concentration: 100 nM
Beside the measured number, compound 3's estimate is 2.5-fold (0.40 log units) below it; measured number inside the range.
By their numbers in this assay, from the lowest: compound 2; then compounds 1 and 3 (each within the scatter of the next).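

In this assay, for the compounds shown here, the replacement of phenyl by 3-chlorophenyl gives a 1.3-fold higher number from compound 1 to compound 3 (0.10 log units; within the scatter) and is the first reading at this place on the ring, the aromatic carbon meta to a large group. The added chlorine, a single heavy atom with no hydrogen-bond donors or acceptors, leaves compound 3 indistinguishable from compound 1 on this read-out, so at this place the core of compound 1 carries a chloro group without a difference that lies beyond the scatter. No measurement at hand bears on why the two compounds read alike.

What the compounds shown leave open is whether this holds for other groups on the same aromatic carbon, such as a carboxylic acid, an amine or a trifluoromethyl group, any of which could read quite differently in this assay. One step also cannot say whether chloro at this place would read the same on the core of compound 2, whose number lies far lower, so the finding stands for the core of compound 1 alone.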